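Carbamoyl for trifluoromethyl in a biaryl aminopyridine series

The compounds below may be only part of what the source reports. "The series", "measured", "known", "first", "only" and "open" are said of these compounds alone.

Measured so far: compound 1 `COc1ccc(-c2cc(-c3cccc(S(C)(=O)=O)c3)cnc2N)cn1`, 25 ug/mL; compound 2 `COc1ccc(-c2cc(-c3ccc(S(N)(=O)=O)cc3)cnc2N)cn1`, 12.5 ug/mL; compound 3 `COc1ccc(-c2cc(-c3ccc(C(F)(F)F)cc3)cnc2N)cn1`, 1.6 ug/mL.

In a physicochemical assay for solubility, read by nephelometry, in phosphate buffer, measured as kinetic solubility, at pH 6.5 (a lower number here means a less soluble compound, a higher number a more soluble compound), compound 3 gives the lowest of the three numbers; compound 2 sits nearest, and compound 1 furthest away. The unmeasured compound 4 `COc1ccc(-c2cc(-c3ccc(C(N)=O)cc3)cnc2N)cn1` differs from compound 3 only in carbamoyl in place of trifluoromethyl on an aromatic carbon. Going by the values given here, the one measured step that bears on this change is a 7.8-fold lower number from compound 2 to compound 3 (0.89 log units; beyond the scatter), where sulfamoyl was replaced by trifluoromethyl. Compound 4 reverses that kind of exchange, placing a group with one hydrogen-bond donor and one acceptor where trifluoromethyl stood. A rise of similar size is therefore expected, a 6.3-fold higher number from compound 3 to compound 4 (0.80 log units; beyond the scatter). Compound 4 is estimated at 10 ug/mL, with a range from 3 ug/mL to 30 ug/mL.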

Compound 4, solubility: 12.5 ug/mL
Estimate against measurement, compound 4: 1.3-fold (0.10 log units) below; the measured number falls inside the stated range.
By their numbers in this assay, from the lowest: compound 3; then compounds 2, 4 and 1 (each within the scatter of the next).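

In this assay the exchange at this position gives a 7.8-fold higher number from compound 3 to compound 4 (0.89 log units; beyond the scatter) and so shows that a group other than sulfamoyl can stand in place of trifluoromethyl with a number well clear of compound 3. Carbamoyl and sulfamoyl are not told apart here, with no change at the digits printed from compound 2 to compound 4 (within the scatter) between them. No measurement offered here accounts for this result. From the compounds shown here alone, whether a nitrile, a carboxylic acid or an aminomethyl group on this aromatic carbon would give a similar number remains open, as does the effect of methylsulfonyl para to a large group.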